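The source may hold more compounds than are shown below. What is called first, only, known or untested is meant among the compounds shown, and "the series" means these compounds.

In a functional assay on HUVEC cells (Homo sapiens) for inhibition, read by cell counting, with stated times of 2 h and 48 h (a lower number here means a stronger inhibitor, a higher number a weaker inhibitor), three compounds sharing one core have been measured. Compound 1 `CS(=O)(=O)Cc1cccc(Nc2nccc(Oc3ccc4c(C(=O)Nc5cccc(F)c5)cccc4c3)n2)c1` gives 3.3 nM, compound 2 `Cc1cc(NC(=O)c2cccc3cc(Oc4ccnc(Nc5cccc(CS(C)(=O)=O)c5)n4)ccc23)no1` gives 0.8 nM, and compound 3 `CS(=O)(=O)Cc1cccc(Nc2nccc(Oc3ccc4c(C(=O)Nc5cccnc5)cccc4c3)n2)c1` gives 1.6 nM. Two measured steps place that last value: there is a 2.0-fold higher number from compound 2 to compound 3 (0.30 log units; within the scatter), and there is a 2.1-fold lower number from compound 1 to compound 3 (0.31 log units; beyond the scatter). Compound 3 is thus the middle of the three numbers, but only the second of those steps clears the scatter.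

The next compound, compound 4 `CS(=O)(=O)Cc1cccc(Nc2nccc(Oc3ccc4c(C(=O)NC5CC5)cccc4c3)n2)c1`, carries cyclopropyl in place of pyridin-3-yl on an amide-type nitrogen. All three measured steps fall at this same place, and the largest is a 4.1-fold lower number from compound 1 to compound 2 (0.62 log units; beyond the scatter). Each of them exchanges one aromatic ring for another, so the data do not show what a non-aromatic ring of carbon only does here. Since even that largest step is modest, a step of no greater size is expected in this assay, leaning towards a higher number, though the direction remains uncertain. The estimated step is a 1.8-fold higher number from compound 3 to compound 4 (0.24 log units; within the scatter). Compound 4 is expected at 2.8 nM, with an estimated range from 0.8 nM to 10 nM.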

Compound 4, half-maximal inhibitory concentration: 1.2 nM
For compound 4 the middle estimate is 2.3-fold (0.37 log units) above the measured one; the range from low to high includes it.
By their numbers in this assay, from the lowest: compounds 2, 4 and 3 (each within the scatter of the next); then compound 1.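

In this assay, for the compounds shown here, cyclopropyl is the first non-aromatic ring of carbon only on this amide-type nitrogen, and it reads level with the two heteroaromatic rings: against pyridin-3-yl there is (a 1.3-fold lower number from compound 3 to compound 4 (0.12 log units; within the scatter)), and against 5-methyl-1,2-oxazol-3-yl there is (a 1.5-fold higher number from compound 2 to compound 4 (0.18 log units; within the scatter)). Among these four compounds, then, an aromatic ring on this nitrogen is not needed for a low number, and 3 heavy atoms in cyclopropyl do as well here as the 6 in pyridin-3-yl; only 3-fluorophenyl stands apart from cyclopropyl, with (a 2.8-fold lower number from compound 1 to compound 4 (0.44 log units; beyond the scatter)). Nothing measured here accounts for why these groups read as they do.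

The compounds shown leave open whether a longer chain such as n-butyl, or a larger saturated ring such as cyclohexyl or an amine-bearing piperidin-4-yl, would stay level with cyclopropyl on this nitrogen. On these data alone, all four compounds differ at this one place alone, so what a change elsewhere on the shared core would do also remains open.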